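The compounds below may be only part of what the source reports. "The series", "measured", "known", "first", "only" and "open" are said of these compounds alone.

Two compounds have been measured in a functional assay on A-431 cells (Homo sapiens) for cytotoxicity, read by MTT assay; on this read-out higher numbers stand for weaker inhibition and lower numbers for stronger inhibition:

Compound 1, `N#Cc1c(NCc2ccccc2)c(F)c2nc(N)nc(N)c2c1F`, gives 12.9 ug/mL.
Compound 2, `N#Cc1c(NCc2ccccc2)c(Cl)c2nc(N)nc(N)c2c1NCc1ccccc1`, gives 716 ug/mL.

Compound 2 stands at the highest of the two numbers in this assay; the nearest is compound 1, whose number is lower by a gap beyond the scatter, so compound 2 is the weaker inhibitor of the pair. The two structures differ in more than one place, and no single step between them is shown, so only their two values speak for that gap.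

Compound 3, `N#Cc1c(NCc2ccccc2)c(F)c2nc(N)nc(N)c2c1NCc1ccccc1`, is to be measured in this assay. It differs from compound 2 by fluoro in place of chloro on an aromatic carbon. Within the data shown here, no measured pair isolates this exchange, so its size is not known from the data. As one single-atom substituent replaces another at the same place, a small step is expected, close to or within the scatter, with a slight lean toward a lower number. The expected step is a 1.8-fold lower number from compound 2 to compound 3 (0.25 log units; within the scatter). Compound 3 is therefore estimated at 400 ug/mL, within a range from 100 ug/mL to 1500 ug/mL.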

Compound 3, half-maximal inhibitory concentration: 20.7 ug/mL
Estimate against measurement, compound 3: 19-fold (1.29 log units) above; the measured number lies below the stated range.
By their numbers in this assay, from the lowest: compounds 1 and 3 (each within the scatter of the next); then compound 2.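

In this assay, the place ortho to a benzylamino group and ortho to a fused ring proves highly sensitive to the identity of its halogen: fluoro in place of chloro gives a 35-fold lower number from compound 2 to compound 3 (1.54 log units; beyond the scatter), a large step beyond the scatter from the exchange of one single atom for another. With fluoro held at that place, benzylamino in place of fluoro on an aromatic carbon gives a 1.6-fold higher number from compound 1 to compound 3 (0.21 log units; within the scatter), which lies within the scatter, so among these three compounds the high number of compound 2 appears only where chloro is present, and the added benzylamino group does not by itself bring such a number. No measurement shown accounts for the size of the chloro-to-fluoro step.

The compounds shown leave open how a bromo, a methyl, a methoxy or an amine would read at this place, so it cannot yet be said whether chloro stands alone or fluoro does. They also leave open whether chloro in place of fluoro would give a step of similar size on the core of compound 1, which has fluoro where compound 3 has its added benzylamino group.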